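Allylamine in Place of Propylamine on a Curcumin-Like Scaffold

The compounds below may be only part of what the source reports. "The series", "measured", "known", "first", "only" and "open" are said of these compounds alone.

Measured compounds:
- compound 1, `CCCNC(=C\C(=O)/C=C/c1ccc(O)c(OC)c1)/C=C/c1ccc(O)c(OC)c1`: > 25000 nM
- compound 2, `CCC(C)NC(=C\C(=O)/C=C/c1ccc(OC(C)=O)c(OC)c1)/C=C/c1ccc(OC(C)=O)c(OC)c1`: > 25000 nM

Compound 1 was tested in a functional assay on CHO-K1 cells (Cricetulus griseus) for inhibition, read by sulforhodamine B assay, with a stated time of 72 h; on this read-out higher numbers stand for weaker inhibition and lower numbers for stronger inhibition. In this assay compound 1 gives only a limit, > 25000 nM, and no number. Compound 2 likewise reaches only a limit in this assay, > 25000 nM. Among the measured compounds shown here, both results therefore sit at the limit of > 25000 nM in this assay, at which 2 of the 2 values shown sit, so compound 1 cannot be placed relative to compound 2 and no step between measured compounds can be read.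

The compound still to be measured is compound 3, `C=CCNC(=C\C(=O)/C=C/c1ccc(O)c(OC)c1)/C=C/c1ccc(O)c(OC)c1`. It differs from compound 1 by vinyl in place of ethyl on a saturated chain carbon bound to an amine nitrogen. For the measured compounds named here, with only a limit for compound 1 and no measured step to lean on, the change from compound 1 to compound 3 is expected to bring nothing beyond the scatter of this assay, and compound 3 is estimated to remain at the limit as well: a step that the limit leaves unreadable from compound 1 to compound 3. Compound 3 is accordingly expected to give about 35000 nM in this assay, within 12000 nM to 100000 nM.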

Compound 3, half-maximal inhibitory concentration: > 25000 nM
Compound 3: a limit, no number (the forecaster's own chance of this, stated with the estimate: 80%); the middle value is on the limit's open side.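

Among the compounds shown here, compound 3, like compound 1, gives only a limit in this assay and no step from compound 1 to compound 3 can be read: the limit of > 25000 nM in this assay, at which 3 of the 3 values shown sit.

The compounds shown leave open whether vinyl in place of ethyl changes inhibition at all, and at what concentration any of them would inhibit these cells.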